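Amide nitrogen groups: from compound 3 to compound 4

This account rests on a few compounds, and the source may have more. Where it says the series, first, only, none or still open, it means among the compounds named here.

Measured so far in a functional assay on BaF3 cells (Mus musculus) for antiproliferative activity, read by CCK-8 assay and cell counting, with a stated time of 76 h (on this read-out lower numbers stand for stronger inhibition and higher numbers for weaker inhibition), on this series:
- compound 1 `COc1cc2nccc(Oc3ccc(Nc4nn(C)cc4C(=O)NCc4ccccc4)cc3)c2cc1C(N)=O` gives > 10000 nM as a limit
- compound 2 `COc1cc2nccc(Oc3ccc(Nc4nn(C)cc4C(=O)NC4CCCCC4)cc3)c2cc1C(N)=O` gives 4800 nM as a number
- compound 3 `COc1cc2nccc(Oc3ccc(Nc4nn(C)cc4C(=O)NCC4CCCCC4)cc3)c2cc1C(N)=O` gives > 10000 nM as a limit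

Compound 3 stands at the limit of > 10000 nM in this assay, at which 2 of the 3 values shown sit, and has no number of its own. The change to compound 4 `COc1cc2nccc(Oc3ccc(Nc4nn(C)cc4C(=O)Nc4cccc(F)c4)cc3)c2cc1C(N)=O` is 3-fluorophenyl in place of cyclohexylmethyl on an amide-type nitrogen and puts 3-fluorophenyl in place of cyclohexylmethyl on an amide-type nitrogen.

Two measured steps at that nitrogen bear on it: an at least 2.0-fold lower number from compound 1 to compound 2 (0.31 log units; beyond the scatter) and an at least 2.0-fold higher number from compound 2 to compound 3 (0.31 log units; beyond the scatter) in this assay. The third, a step that the two limits leave unreadable from compound 1 to compound 3, gives no size. Among these compounds a number appears only with cyclohexyl on that nitrogen, while the two groups with a saturated chain carbon there stay at the limit. 3-fluorophenyl has no such chain carbon, so compound 4 is expected to resemble compound 2 with 4800 nM rather than the limit. For the measured compounds named here, no measured compound carries an aromatic ring there without that chain carbon, and the range stays wide.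

The expected change is an at least 5.0-fold lower number from compound 3 to compound 4 (0.69 log units; beyond the scatter) in this assay, toward a lower number and beyond the scatter. For compound 4 the estimated value is 2000 nM, with an expected range of 300 nM to 10000 nM in this series.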

Compound 4, half-maximal inhibitory concentration: 4480 nM
Beside the measured number, compound 4's estimate is 2.2-fold (0.35 log units) below it; the range from low to high includes it.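

In this assay, 3-fluorophenyl is a second group on the amide-type nitrogen that gives a number, and it stands level with cyclohexyl: a 1.1-fold lower number from compound 2 to compound 4 (0.03 log units; within the scatter). Set against the two groups with a saturated chain carbon on that nitrogen, an aromatic ring bound directly there gives an at least 2.2-fold lower number from compound 3 to compound 4 (0.34 log units; beyond the scatter) and an at least 2.2-fold lower number from compound 1 to compound 4 (0.34 log units; beyond the scatter), and both sizes are only bounds, as each step starts from a limit and not from a number. Among these four compounds, a number therefore appears with a six-membered ring bound directly to the nitrogen, saturated in compound 2 and aromatic in compound 4, and no compound shown goes against this, while the two compounds with a chain carbon there stay at the limit: the limit of > 10000 nM in this assay, at which 2 of the 4 values shown sit.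

Whether the fluorine contributes anything remains open, as the comparison with an unsubstituted phenyl on that nitrogen is missing from the compounds shown, and so does the effect of moving it, as in 4-fluorophenyl. Also open, as far as these compounds go, is whether any other group at this nitrogen, such as cyclopentyl or a pyridyl ring, gives a clearly lower number than compound 2 and compound 4 do.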